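The source may report more compounds than this note shows. Statements on the series, on what has been measured and on what is new or still open speak of the compounds shown alone.

Compound 1 `CC(C)(C)N1C[C@@H](C(=O)Nc2nccn2Cc2cccc(Cl)c2)[C@H](c2ccc(F)cc2F)C1` gives 1270 nM in a functional assay for agonist activity at Melanocyte-stimulating hormone receptor (Homo sapiens), read by cAMP accumulation; a lower number here means that less compound is needed, a higher number that more compound is needed for the effect; compound 2 `CC(C)(C)N1C[C@@H](C(=O)Nc2nccn2Cc2ccccc2)[C@H](c2ccc(F)cc2F)C1` gives 4660 nM. Compound 3 `CC(C)(C)N1C[C@@H](C(=O)Nc2nccn2Cc2ccc(Cl)cc2)[C@H](c2ccc(F)cc2F)C1` reaches only the limit of the assay, > 10000 nM.

Compound 2 sits as the higher of the two numbers, since the step of a 3.7-fold higher number from compound 1 to compound 2 (0.56 log units; beyond the scatter) is a chloro removed. Compound 4 `CC(C)(C)N1C[C@@H](C(=O)Nc2nccn2Cc2ccccc2N2CCC(CC(=O)O)CC2)[C@H](c2ccc(F)cc2F)C1` arises from compound 2 by 4-(carboxymethyl)piperidin-1-yl in place of hydrogen on an aromatic carbon. For the measured compounds named here, no measured step concerns this ring position or this kind of group; the steps of an at least 7.8-fold higher number from compound 1 to compound 3 (0.89 log units; beyond the scatter) and an at least 2.1-fold higher number from compound 2 to compound 3 (0.33 log units; beyond the scatter) only show that where a small group sits on this ring moves the number well beyond the scatter. Compound 4 is therefore expected near compound 2, with a wide range, the step being estimated as a 1.6-fold lower number from compound 2 to compound 4 (0.19 log units; within the scatter). The estimate for compound 4 is 3000 nM, between 600 nM and 15000 nM.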

Compound 4, half-maximal effective concentration: 1980 nM
The estimate for compound 4 lay 1.5-fold (0.18 log units) above the measured number; the measured number falls inside the stated range.
By their numbers in this assay, from the lowest: compounds 1 and 4 (each within the scatter of the next); then compound 2. At a limit, above all of these: compound 3.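

Compound 4 shows that the benzyl ring of the shared core accepts a large substituent on this aromatic carbon, ortho to a large group: in this assay, 4-(carboxymethyl)piperidin-1-yl in place of hydrogen gives a 2.4-fold lower number from compound 2 to compound 4 (0.37 log units; beyond the scatter). The earlier compounds shown here carried only hydrogen or chloro on this ring, so they showed nothing about a group of this size. Nothing at hand gives a reason for this step.

The compounds shown leave open whether the step belongs to the carboxylic acid or to the piperidine ring that carries it. They also leave open how a simple amine or a longer chain ending in a carboxylic acid would compare at this place.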